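A few compounds are considered here, and "the series" means these few. Any claim that something is new, unique, unknown or untested is made for them only; others in the source may bear on it.

Measured compounds:
- compound 1, `CS(=O)(=O)NCCN1CCC(CNC(=O)c2cccc3[nH]cnc23)CC1`: 11.4 nM
- compound 2, `CCCCCN1CCC(CNC(=O)c2cc(Cl)cc3[nH]cnc23)CC1`: 0.54 nM
- compound 3, `CCCCN1CCC(CNC(=O)c2cc(Br)cc3[nH]cnc23)CC1`: 0.64 nM

All three numbers come from an assay on membranes from striatum for binding affinity to 5-hydroxytryptamine receptor 4 (Rattus norvegicus); on this read-out lower numbers stand for stronger inhibition and higher numbers for weaker inhibition. Compound 3 gives 0.64 nM, the second highest of the three numbers. Its nearest neighbour is compound 2 with 0.54 nM, a gap within the scatter, so the two cannot be told apart on this read-out. The furthest is compound 1 with 11.4 nM, a gap beyond the scatter, so compound 1 is the weaker binder of the set by a clear margin.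

Compound 4, `CCCCN1CCC(CNC(=O)c2cc(Br)c([N+](=O)[O-])c3[nH]cnc23)CC1`, has not been measured in this assay. It differs from compound 3 in one place: nitro in place of hydrogen on an aromatic carbon. Going by the values given here, no measured pair shows this change, so its effect is unknown. Since compound 3 sits at a strong value, and the change leaves the rest of the molecule intact, a small step is expected, with no clear direction beyond the scatter, leaning slightly toward a weaker number. The estimated step from compound 3 to compound 4 is a 1.6-fold higher number from compound 3 to compound 4 (0.19 log units; within the scatter). Compound 4 is expected to give about 1 nM, with a range from 0.3 nM to 4 nM.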

Compound 4, inhibition constant: 48.2 nM
For compound 4 the middle estimate is 48-fold (1.68 log units) below the measured one; the whole stated range lies below it.
By their numbers in this assay, from the lowest: compounds 2 and 3 (each within the scatter of the next); then compound 1; then compound 4.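

In this assay, nitro in place of hydrogen on the aromatic carbon ortho to a bromo group gives a 75-fold higher number from compound 3 to compound 4 (1.88 log units; beyond the scatter), a large step beyond the scatter. The earlier compounds shown here all carry hydrogen on this carbon and say nothing about substitution there; this step shows that the position is not indifferent to what it holds, and that adding nitro to the strong binder compound 3 costs much of its binding affinity. Nothing measured here accounts for the size of this loss.

On these data alone, whether the loss belongs to nitro itself or to any group on this carbon remains open; an amine, a methyl or a fluoro group at the same place would separate the two. Also open, as far as these compounds go, is whether the step depends on the bromo group, which a chloro group or hydrogen in its place would test.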